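The compounds below may be only part of what the source reports. "The series", "measured", "known", "first", "only" and "open" are said of these compounds alone.

Measured compounds: compound 1 `C[C@H]1C[C@@H]1C(=O)N1CC2CNCC2C1` with 34000 nM in an assay on CHO cells for agonist activity at Neuronal acetylcholine receptor; alpha3/beta4 (Homo sapiens), read by FLIPR and calcium flux; on this read-out higher numbers stand for an effect only at larger amounts of compound and lower numbers for an effect already at smaller amounts; compound 2 `CC(=O)N1CC2CNCC2C1` with 23000 nM in this assay.

Within the data shown here, compound 2 has the lowest of the two numbers so far; its nearest neighbour, compound 1, differs only within the scatter. Compound 3 `COC(=O)N1CC2CNCC2C1` is not yet measured; it differs from compound 2 by methoxy in place of methyl on a carbonyl carbon. Among the measured compounds shown here, the one measured step at the same carbonyl carbon, a 1.5-fold lower number from compound 1 to compound 2 (0.17 log units; within the scatter), stayed within the scatter. No step beyond the scatter is therefore expected for compound 3, and its estimated step is a 1.1-fold higher number from compound 2 to compound 3 (0.04 log units; within the scatter). For compound 3 the expected value in this assay is 25000 nM, within 9000 nM to 70000 nM.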

Compound 3, half-maximal effective concentration: 16000 nM
Estimate against measurement, compound 3: 1.6-fold (0.19 log units) above; measured number inside the range.
By their numbers in this assay, from the lowest: compounds 3, 2 and 1 (each within the scatter of the next, the first and the last beyond it).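

In this assay methoxy in place of methyl on the carbonyl carbon, which adds one hydrogen-bond acceptor by count, gives a 1.4-fold lower number from compound 2 to compound 3 (0.16 log units; within the scatter) and so leaves the number within the scatter. Among these compounds, only the wider exchange of 2-methylcyclopropyl for methoxy gives a 2.1-fold lower number from compound 1 to compound 3 (0.33 log units; beyond the scatter) and with it the first step beyond the scatter at this carbonyl carbon, a modest one. Nothing available gives a reason for either step.

Open, from the compounds shown here alone, is whether an amine or a longer alkoxy such as ethoxy on this carbonyl carbon would stay in the same range. Also open, going by these compounds, is whether any group at this place moves the number far from these values.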